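Swapping Propyl for Amino on the Benzamide Arm

The source may hold more compounds than are shown below. What is called first, only, known or untested is meant among the compounds shown, and "the series" means these compounds.

The measured compounds, each in an assay on isolated protein for inhibition of Rho-associated protein kinase 1 (Homo sapiens), read by scintillation counting, radiometric assay and 33P incorporation, with a stated time of 40 min, in the presence of a further agent that is not named here; a lower number here means a stronger inhibitor, a higher number a weaker inhibitor:
Compound 1, `CCCc1ccc(C(=O)Nc2cccc(NC(=O)COc3ccc4c(=O)ccoc4c3)c2)cc1`, gives 143 nM.
Compound 2, `CN(C)c1ccc(S(=O)(=O)Nc2cccc(NC(=O)COc3ccc4c(=O)ccoc4c3)c2)cc1`, gives 803 nM.
Compound 3, `O=C(COc1ccc2c(=O)ccoc2c1)Nc1cccc(NS(=O)(=O)c2ccc(OC(F)(F)F)cc2)c1`, gives 6440 nM.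

Among these three, compound 1 has the lowest number, and both gaps to the others are beyond the scatter: compound 2 sits higher, and compound 3 higher still. Within the data shown here, the one step that can be traced between two measured compounds is an 8.0-fold higher number from compound 2 to compound 3 (0.90 log units; beyond the scatter), which shows that changing the group on the outer aromatic ring can move the result by a clear margin.

Compound 4, `Nc1ccc(C(=O)Nc2cccc(NC(=O)COc3ccc4c(=O)ccoc4c3)c2)cc1`, differs from compound 1 by amino in place of propyl on an aromatic carbon. Among the measured compounds shown here, no measured pair changes the same group, so the expectation rests on the looser lesson from compound 2 and compound 3, namely that such a swap on this ring can carry a modest shift in either direction. A step of about a 1.8-fold higher number from compound 1 to compound 4 (0.26 log units; within the scatter) is expected, with the direction uncertain and a mild weakening taken as the more likely outcome. Compound 4 is therefore estimated at 260 nM, within a range from 70 nM to 950 nM.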

Compound 4, half-maximal inhibitory concentration: 802 nM
The estimate for compound 4 lay 3.1-fold (0.49 log units) below the measured number; the range from low to high includes it.
By their numbers in this assay, from the lowest: compound 1; then compounds 4 and 2 (each within the scatter of the next); then compound 3.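

In this assay, the change from 4-propylphenyl to 4-aminophenyl gives a 5.6-fold higher number from compound 1 to compound 4 (0.75 log units; beyond the scatter), so inhibition is clearly weaker with amino than with propyl at this position on the benzamide arm. Among these compounds, the earlier step, an 8.0-fold higher number from compound 2 to compound 3 (0.90 log units; beyond the scatter), came from the sulfonamide-linked compounds and involved other groups, so this is the first measured step on the benzamide arm, and it shows that this ring position also responds to the group it carries. The swap removes a three-carbon chain and brings in a hydrogen-bond donor and acceptor at once, and no measurement here accounts for the weaker result or separates those two differences.

The compounds shown leave open whether the result tracks the chain or the nitrogen: ethyl or butyl in place of propyl would test the first, and methylamino or dimethylamino on this same benzamide ring would test the second. Going by these compounds, whether the swap from propyl to amino would have a similar effect on the sulfonamide-linked compounds also remains open.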